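Swapping 3,5-dichlorophenyl for 3-methoxyphenyl

The compounds below may be only part of what the source reports. "The series", "measured", "known", "first", "only" and "open" are said of these compounds alone.

In a functional assay on HL-60 cells (Homo sapiens) for inhibition, read by MTT assay, with a stated time of 72 h (a higher number here means a weaker inhibitor, a lower number a stronger inhibitor), compound 3 `Cc1nc(-c2ccc(F)cc2)c(C(=O)N2CCN(c3cc(Cl)cc(Cl)c3)CC2)o1` gives 52.1 nM. That is level, within the scatter, with compound 2 `COc1cccc(N2CCN(C(=O)c3oc(C)nc3-c3ccccc3F)CC2)c1` at 56.1 nM, and well under compound 1 `Cc1ccc(C)c(N2CCN(C(=O)c3oc(C)nc3-c3ccc(F)cc3)CC2)c1` at 358 nM. Among the measured compounds shown here, the only measured step, a 6.9-fold lower number from compound 1 to compound 3 (0.84 log units; beyond the scatter), is a modest one: 3,5-dichlorophenyl in place of 2,5-dimethylphenyl, so a swap at this ring nitrogen can move the number. Compound 4 `COc1cccc(N2CCN(C(=O)c3oc(C)nc3-c3ccc(F)cc3)CC2)c1` instead carries 3-methoxyphenyl in place of 3,5-dichlorophenyl on an amine nitrogen in a ring. Though it differs from compound 4 elsewhere, compound 2 has the same 3-methoxyphenyl group and reads 56.1 nM. The expected step in this assay, a 1.3-fold higher number from compound 3 to compound 4 (0.13 log units; within the scatter), therefore stays within the scatter. The estimate for compound 4 is 70 nM, with an expected range of 25 nM to 200 nM.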

Compound 4, half-maximal inhibitory concentration: 112 nM
The estimate for compound 4 lay 1.6-fold (0.20 log units) below the measured number; the measured number falls inside the stated range.
By their numbers in this assay, from the lowest: compounds 3, 2 and 4 (each within the scatter of the next, the first and the last beyond it); then compound 1.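

On an amine nitrogen in a ring, the result separates 3-methoxyphenyl from both other groups. In this assay, replacing 3,5-dichlorophenyl gives a 2.1-fold higher number from compound 3 to compound 4 (0.33 log units; beyond the scatter), while replacing 2,5-dimethylphenyl gives a 3.2-fold lower number from compound 1 to compound 4 (0.50 log units; beyond the scatter), so 3-methoxyphenyl falls in the middle. On an aromatic carbon elsewhere in the molecule, 4-fluorophenyl in place of 2-fluorophenyl gives a 2.0-fold higher number from compound 2 to compound 4 (0.30 log units; within the scatter), so that change shows no clear effect.

From the compounds shown here alone, how an amine or a carboxylic acid would fare on this nitrogen's phenyl ring remains open. Nothing available explains why these groups differ.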